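Chloro in Place of Amino: What Compound 4 Should Show

The source may hold more compounds than are shown below. What is called first, only, known or untested is meant among the compounds shown, and "the series" means these compounds.

The compounds measured so far, in a functional assay on T47D cells (Homo sapiens) for cytotoxicity, read by sulforhodamine B assay, with a stated time of 48 h; on this read-out lower numbers stand for higher toxicity in this test and higher numbers for lower toxicity in this test:
compound 1 `Nc1nc(Cl)c2ncn(Cc3ccccc3CCl)c2n1` gives > 100000 nM
compound 2 `ClCc1ccccc1Cn1cnc2nc(Cl)nc(Cl)c21` gives > 100000 nM
compound 3 `ClCc1ccc(Cn2cnc3c(Cl)nc(Cl)nc32)cc1` gives > 100000 nM

Compound 1 stands at a limit of this assay, so its value is a limit and not a number. The value of compound 2 is likewise a limit. The value of compound 3 is also a limit. All three values shown sit at the limit of > 100000 nM in this assay, at which 3 of the 3 values shown sit.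

Compound 4 `ClCc1ccccc1Cn1cnc2c(Cl)nc(Cl)nc21` arises from compound 1 by the change (chloro in place of amino on an aromatic carbon). No step between measured compounds is shown, so its size is not known from the data. Because every measured value sits at the limit of > 100000 nM in this assay, at which 3 of the 3 values shown sit, the step of a number no higher from compound 1 to compound 4 (the limit leaves the size open) is expected to be none beyond the scatter, with compound 4 most likely also reported as a limit. Compound 4 is thus expected at 100000 nM, within 30000 nM to 300000 nM.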

Compound 4, concentration lethal to 50% of the cells: > 100000 nM
Compound 4 ended at the assay's limit (the forecaster's own chance of this, stated with the estimate: 85%); the middle value lies on the limit itself.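

Within the data shown here, no step from compound 1 to compound 4 can be read, since both values are limits: the limit of > 100000 nM in this assay, at which 4 of the 4 values shown sit. The compounds shown leave open whether chloro in place of amino on an aromatic carbon alters the read-out in this assay, and how the four compounds rank.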